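Replacing 6-bromopyridin-2-yl with 2-methoxyphenyl

A few compounds are considered here, and "the series" means these few. Any claim that something is new, unique, unknown or untested is made for them only; others in the source may bear on it.

Measured in a functional assay on A549 cells (Homo sapiens) for antiproliferative activity, read by MTT assay; on this read-out lower numbers stand for stronger inhibition and higher numbers for weaker inhibition:
- compound 1 `O=C1N=C(N2CCC[C@H]2C(=O)Nc2ccc3ncnc(Nc4cccc(Cl)c4)c3c2)S/C1=C/c1ccccc1Cl`: > 50000 nM (a limit)
- compound 2 `O=C1N=C(N2CCC[C@H]2C(=O)Nc2ccc3ncnc(Nc4cccc(Cl)c4)c3c2)S/C1=C/c1cccs1`: 6100 nM
- compound 3 `O=C1N=C(N2CCC[C@H]2C(=O)Nc2ccc3ncnc(Nc4cccc(Cl)c4)c3c2)S/C1=C/c1cccc(Br)n1`: 3100 nM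

The result for compound 1 is a limit of the assay, not a number. Compound 3 has one close neighbour, with a 2.0-fold lower number from compound 2 to compound 3 (0.29 log units; within the scatter), so the two cannot be ranked. Compound 4 `COc1ccccc1/C=C1/SC(N2CCC[C@H]2C(=O)Nc2ccc3ncnc(Nc4cccc(Cl)c4)c3c2)=NC1=O` carries 2-methoxyphenyl in place of 6-bromopyridin-2-yl on a double-bonded chain carbon bound to a double-bonded ring carbon.

Among the measured compounds shown here, the closest precedent is compound 1, which has 2-chlorophenyl at the same place. Two measured steps lead away from it, an at least 8.1-fold lower number from compound 1 to compound 2 (0.91 log units; beyond the scatter) and an at least 16-fold lower number from compound 1 to compound 3 (1.20 log units; beyond the scatter). A single compound is thin evidence, and 2-chlorophenyl is not 2-methoxyphenyl, so only part of that large step is expected to return, towards a higher number in this assay. The expected change is a 4.8-fold higher number from compound 3 to compound 4 (0.68 log units; beyond the scatter). Compound 4 is estimated at 15000 nM, with an expected range of 4000 nM to 50000 nM.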

Compound 4, half-maximal inhibitory concentration: > 50000 nM
Compound 4: a limit, no number; the forecaster's own chance of this, stated with the estimate: 25%; middle value at least 3.3-fold (0.52 log units) away from the limit.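

Compound 4 gives a limit, not a number, in this assay, and it is the second compound shown at that limit: the limit of > 50000 nM in this assay, at which 2 of the 4 values shown sit.

With 2-methoxyphenyl at this place, the readable steps are an at least 16-fold higher number from compound 3 to compound 4 (1.20 log units; beyond the scatter) and an at least 8.1-fold higher number from compound 2 to compound 4 (0.91 log units; beyond the scatter). Among the compounds shown, the two substituted phenyl groups, 2-chlorophenyl in compound 1 and 2-methoxyphenyl in compound 4, now both give limits, whereas thiophen-2-yl in compound 2 and 6-bromopyridin-2-yl in compound 3 give numbers, and the step between compound 1 and compound 4 cannot be read.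

Going by these compounds, it remains open whether an unsubstituted phenyl at this place would give a number rather than a limit. On these data alone, it is also open whether a pyridin-2-yl without the bromine, or a thiophen-2-yl carrying a bromine, would differ from compound 2 and compound 3.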